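Swapping a methylfuran for a methylphenyl on an acrylonitrile amide

This account rests on a few compounds, and the source may have more. Where it says the series, first, only, none or still open, it means among the compounds named here.

Of the compounds shown here, three that share an acrylonitrile chain have been tested in a functional assay on SJ-G2 cells (Homo sapiens) for inhibition, read by MTT assay, with a stated time of 72 h; a higher number here means a weaker inhibitor of growth, a lower number a stronger inhibitor of growth. Compound 1 `N#C/C(=C\c1c[nH]c2ccccc12)C(=O)c1c[nH]c2ccccc12` carries two indole rings and gives 13000 nM. Compound 2 `N#C/C(=C\c1ccc[nH]1)C(=O)NCc1ccc(Cl)c(Cl)c1`, with a pyrrole on the chain and a dichlorobenzyl amide, reaches only the assay limit in this assay, reported as > 50000 nM; that is a limit and not a number, and the limit of > 50000 nM in this assay, at which 1 of the 3 values shown sits, describes it. Compound 3 `COc1ccc(CNC(=O)/C(C#N)=C/c2ccc(C)o2)cc1`, with a methoxybenzyl amide and a 5-methylfuran-2-yl on the chain, gives 75000 nM in this assay, which is the higher of the two numbers that were obtained, and the gap to compound 1 lies beyond the usual scatter.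

The next compound keeps the amide side of compound 3 and changes the ring on the chain: compound 4 `COc1ccc(CNC(=O)/C(C#N)=C/c2ccc(C)cc2)cc1` differs by 4-methylphenyl in place of 5-methylfuran-2-yl on a double-bonded chain carbon bound to a double-bonded chain carbon. Going by the values given here, no pair among the measured compounds differs in a single place, so there is no measured step to lean on. Compound 4 is therefore expected to stay close to compound 3, with a step of a 1.1-fold lower number from compound 3 to compound 4 (0.03 log units; within the scatter) that should not exceed the scatter in either direction. The estimate for compound 4 in this assay is 70000 nM, within a range from 25000 nM to 200000 nM.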

Compound 4, concentration for 50% growth inhibition: 39000 nM
For compound 4 the middle estimate is 1.8-fold (0.25 log units) above the measured one; low and high end bracket the measured number.
By their numbers in this assay, from the lowest: compound 1; then compounds 4 and 3 (each within the scatter of the next).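

This is the first pair among the compounds shown that differs in one place only, so the ring on the chain can now be judged with the rest of the molecule held fixed. In this assay the exchange gives a 1.9-fold lower number from compound 3 to compound 4 (0.28 log units; within the scatter), so a five-membered aromatic ring with one hetero atom and a six-membered aromatic ring of carbon only cannot be told apart in this read-out, even though the exchange also removes a hydrogen-bond acceptor and adds a heavy atom. Within this pair, then, the methoxybenzyl amide series tolerates either ring at this place without a real shift in the number, and nothing available explains that outcome.

As far as these compounds go, it remains open whether a ring carrying an amine or a carboxylic acid at this place on the chain would move the number beyond the scatter. From the compounds shown here alone, it is also open whether the same exchange of 5-methylfuran-2-yl for 4-methylphenyl would give a similar result with another amide side, such as the dichlorobenzyl amide of compound 2.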